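Substituent changes on the pendant aromatic ring: cytotoxicity notes

The source may report more compounds than this note shows. Statements on the series, on what has been measured and on what is new or still open speak of the compounds shown alone.

Measured so far in a functional assay on MCF7 cells (Homo sapiens) for cytotoxicity, read by MTT assay, with a stated time of 72 h; a higher number here means a weaker inhibitor, a lower number a stronger inhibitor:
compound 1 `COc1ccc(-n2ccc(=O)c(C(=O)Nc3ccc(Oc4ccnc5[nH]ccc45)cc3)n2)cc1`: 21600 nM
compound 2 `O=C(Nc1ccc(Oc2ccnc3[nH]ccc23)cc1)c1nn(-c2ccc(Br)cc2)ccc1=O`: 7890 nM
compound 3 `O=C(Nc1ccc(Oc2ccnc3[nH]ccc23)cc1)c1nn(-c2ccccc2)ccc1=O`: 15600 nM

Compound 3, with 15600 nM, sits within the scatter of both other compounds: a 1.4-fold lower number from compound 1 to compound 3 (0.14 log units; within the scatter) and a 2.0-fold higher number from compound 2 to compound 3 (0.30 log units; within the scatter). Among the measured compounds shown here, the only step in the set that passes the scatter is a 2.7-fold lower number from compound 1 to compound 2 (0.44 log units; beyond the scatter), a modest one.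

Compound 4 `O=C(Nc1ccc(Oc2ccnc3[nH]ccc23)cc1)c1nn(-c2ccc(Br)cc2F)ccc1=O` differs from compound 3 by 4-bromo-2-fluorophenyl in place of phenyl on an aromatic nitrogen. Part of this change has a measured counterpart: the bromo-for-hydrogen exchange runs in reverse of a 2.0-fold higher number from compound 2 to compound 3 (0.30 log units; within the scatter), which on its own stayed within the scatter. Nothing measured bears on the added fluorine, so the expectation rests on the bromo step alone. A modest lowering in this assay is expected, of about the size seen between compound 3 and compound 2, with no firm basis for anything larger.

Compound 4 is therefore estimated at 6500 nM, with a range from 2500 nM to 18000 nM. The expected step is a 2.4-fold lower number from compound 3 to compound 4 (0.38 log units; beyond the scatter), which may or may not clear the scatter.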

Compound 4, half-maximal inhibitory concentration: 17900 nM
Estimate against measurement, compound 4: 2.8-fold (0.44 log units) below, and the stated range covers the measured number.
By their numbers in this assay, from the lowest: compounds 2, 3, 4 and 1 (each within the scatter of the next, the first and the last beyond it).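

In this assay, among the compounds shown here, the added fluoro is the one change at this position that clears the scatter, with a 2.3-fold higher number from compound 2 to compound 4 (0.36 log units; beyond the scatter), though the step is modest. Taken as a whole, the 4-bromo-2-fluorophenyl group cannot be told apart from the groups it replaces, with a 1.1-fold higher number from compound 3 to compound 4 (0.06 log units; within the scatter) against phenyl and a 1.2-fold lower number from compound 1 to compound 4 (0.08 log units; within the scatter) against 4-methoxyphenyl, so the small gain of compound 2 over compound 1 does not carry over to compound 4. No measurement in hand accounts for this step.

The compounds shown leave open whether fluoro without the bromo would shift the number at all, and so whether the step from compound 2 depends on the bromo being present. They also leave open whether a different kind of group on the pendant ring, such as an amine, a carboxylic acid or a trifluoromethyl, would move the number beyond the narrow band these four compounds occupy.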